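The source may report more compounds than this note shows. Statements on the series, on what has been measured and on what is new or still open speak of the compounds shown alone.

Compound 2 `COc1ccc(C(=O)/C=C/c2cc(-c3cc(OC)c(OC)c(OC)c3)n[nH]2)cc1` gives 86% in a functional assay on A549 cells (Homo sapiens) for cytotoxicity, read by sulforhodamine B assay, with a stated time of 48 h, tested at 1 uM (on this read-out higher numbers stand for a weaker effect at the one concentration tested and lower numbers for a stronger effect), and compound 1 `COc1ccc(C(=O)/C=C/c2cc(-c3cc(OC)c(OC)c(OC)c3)n[nH]2)cc1OC` gives 84%, so the two sit within the scatter of each other. For the measured compounds named here, the only measured step, a number 2 percentage points higher from compound 1 to compound 2 (within the scatter), concerns a hydrogen in place of methoxy on an aromatic carbon, not the carbonyl side. Compound 3 `COc1cc(-c2cc(/C=C/C(=O)c3ccc(F)c(F)c3)[nH]n2)cc(OC)c1OC` differs from compound 2 by 3,4-difluorophenyl in place of 4-methoxyphenyl on a carbonyl carbon. Going by the values given here, no measured step touches this position, so the expectation rests only on compound 2 itself. Compound 3 is therefore expected to give 84%, between 68% and 96%, a step of a number 2 percentage points lower from compound 2 to compound 3 (within the scatter) that is expected to stay within the scatter.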

Compound 3, a percentage reported as activity, at one concentration (the size of the read-out at that concentration, not a potency): 82%
Compound 3: the middle estimate sits 2 percentage points above what was measured; measured number inside the range.
By their numbers in this assay, from the lowest: compounds 3, 1 and 2 (each within the scatter of the next).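

In this assay the carbonyl side now has readings of its own: there is a number 4 percentage points lower from compound 2 to compound 3 (within the scatter) for the 4-methoxyphenyl exchange and a number 2 percentage points lower from compound 1 to compound 3 (within the scatter) for the 3,4-dimethoxyphenyl exchange. On this carbonyl carbon, then, 3,4-difluorophenyl in place of either methoxy-bearing phenyl leaves the read-out within the scatter. Nothing measured here offers an explanation for this.

From the compounds shown here alone, whether an amine or a carboxylic acid on this phenyl ring, or a saturated chain in its place, would move the number beyond the scatter remains open. A reading at one concentration also tells only how strong or weak the effect is at that concentration.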